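The compounds below may be only part of what the source reports. "The series", "measured", "known", "first", "only" and "open" are said of these compounds alone.

Of the compounds shown here, three sharing one core have been tested in a functional assay on MDA-MB-231 cells (Homo sapiens) for antiproliferative activity, read by MTT assay, with a stated time of 48 h; a lower number here means a stronger inhibitor, a higher number a weaker inhibitor: compound 1 `C/C(=C\CC/C(C)=C/CC[C@@H]1[C@@]2(C)CCC(=O)C(C)(C)[C@H]2CC[C@@]1(C)O)CC/C=C(\C)C(=O)OCc1cn(-c2ccc(C(F)(F)F)cc2)nn1`, compound 2 `C/C(=C\CC/C(C)=C/CC[C@@H]1[C@@]2(C)CCC(=O)C(C)(C)[C@H]2CC[C@@]1(C)O)CC/C=C(\C)C(=O)OCc1cn(-c2ccccc2C(F)(F)F)nn1` and compound 3 `C/C(=C\CC/C(C)=C/CC[C@@H]1[C@@]2(C)CCC(=O)C(C)(C)[C@H]2CC[C@@]1(C)O)CC/C=C(\C)C(=O)OCc1cn(-c2ccccc2C)nn1`. Compound 1 gives > 150000 nM, which is a limit of the assay and not a number. Compound 2 gives > 150000 nM, again a limit. Compound 3 gives > 150000 nM, also a limit. Compound 3 thus stands with the other two, and no number separates them: the limit of > 150000 nM in this assay, at which 3 of the 3 values shown sit.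

Compound 4 `C/C(=C\CC/C(C)=C/CC[C@@H]1[C@@]2(C)CCC(=O)C(C)(C)[C@H]2CC[C@@]1(C)O)CC/C=C(\C)C(=O)OCc1cn(-c2cccc(Cl)c2)nn1` keeps the core and carries 3-chlorophenyl in place of 2-methylphenyl on an aromatic nitrogen. Among the measured compounds shown here, none of the measured compounds carries the 3-chlorophenyl group. The measured steps that bear on this change alter the group on that same nitrogen, or a group on its phenyl: a step that the two limits leave unreadable from compound 1 to compound 2, a step that the two limits leave unreadable from compound 1 to compound 3 and a step that the two limits leave unreadable from compound 2 to compound 3. None of them has a readable size, so they point in no direction, and no step beyond the scatter can be expected from them. Compound 4 is therefore expected to stay in the same region as compound 3, and it will most likely be reported as a limit too. The expected step is a step that the limit leaves unreadable from compound 3 to compound 4. For compound 4 the estimate is 170000 nM, with an expected range from 70000 nM to 400000 nM.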

Compound 4, half-maximal inhibitory concentration: 103000 nM
For compound 4 the middle estimate is 1.7-fold (0.22 log units) above the measured one, and the stated range covers the measured number.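

In this assay compound 4, with 3-chlorophenyl on the aromatic nitrogen, gives 103000 nM, the only number among the compounds shown. The other three remain limits and not numbers, and the steps among them cannot be read: the limit of > 150000 nM in this assay, at which 3 of the 4 values shown sit.

On these data alone, the change to 3-chlorophenyl on this nitrogen now gives an at least 1.4-fold lower number from compound 3 to compound 4 (0.16 log units; that floor lies within the scatter), an at least 1.4-fold lower number from compound 2 to compound 4 (0.16 log units; that floor lies within the scatter) and an at least 1.4-fold lower number from compound 1 to compound 4 (0.16 log units; that floor lies within the scatter), so each step is known only as a floor and its true size stays open.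

As far as these compounds go, it remains open whether the result depends on the chlorine itself or on where it sits on the phenyl ring, a question that a 3-methylphenyl, 2-chlorophenyl or 4-chlorophenyl group on the same nitrogen would address. Equally open, from the compounds shown here alone, is how far the result extends to other groups at this nitrogen, such as 3-methoxyphenyl or 3-bromophenyl, or to an amide in place of the ester that joins the triazole side to the shared core.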